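The source may report more compounds than this note shows. Statements on the series, on what has been measured and on what is new or still open speak of the compounds shown alone.

Among the measured compounds shown here, in a functional assay on ZR-75-1 cells (Homo sapiens) for cytotoxicity, read by sulforhodamine B assay, with a stated time of 3 days (on this read-out higher numbers stand for an effect only at larger amounts of compound and lower numbers for an effect already at smaller amounts), compound 1 `COc1c(-c2occ(C)c2COC(C)=O)ccc2c1CCCC2(C)C` gives 15.5 uM and compound 2 `COCc1c(C)coc1-c1ccc2c(c1OC)CCCC2(C)C` gives 14.3 uM, so compound 2 cannot be told apart from the only other measured compound. Compound 3 `COc1c(-c2occ(C)c2CO)ccc2c1CCCC2(C)C` differs from compound 2 by hydrogen in place of methyl on an oxygen on a saturated carbon, turning methoxymethyl into hydroxymethyl. For the measured compounds named here, the one measured step on that same kind of oxygen, a 1.1-fold lower number from compound 1 to compound 2 (0.03 log units; within the scatter), stays within the scatter, though it never reveals a free hydroxyl. No shift beyond the scatter is therefore expected in this assay, with an estimated 1.0-fold higher number from compound 2 to compound 3 (0.02 log units; within the scatter). For compound 3 the expected value is 15 uM, within an estimated range of 6 uM to 35 uM.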

Compound 3, concentration for half-maximal effect: 15 uM
The estimate for compound 3 equals the measured number at the digits printed; measured number inside the range.
By their numbers in this assay, from the lowest: compounds 2, 3 and 1 (each within the scatter of the next).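

In this assay, hydrogen in place of methyl on this oxygen (a 1.0-fold higher number from compound 2 to compound 3 (0.02 log units; within the scatter)) and hydrogen in place of acetyl on it (a 1.0-fold lower number from compound 1 to compound 3 (0.01 log units; within the scatter)) both stay within the scatter. Among the compounds shown here, a free hydroxyl is now seen at this position for the first time, and hydroxymethyl cannot be told apart from methoxymethyl or from the acetyl-capped form.

From the compounds shown here alone, whether an amine or a carboxylic acid on this carbon, or a longer chain on this oxygen, would give similar numbers remains open, as do changes elsewhere on the shared core. No measurement at hand explains why these three compounds read alike.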